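Methyl on the Aromatic Ring and Paw Edema Inhibition

The source may hold more compounds than are shown below. What is called first, only, known or untested is meant among the compounds shown, and "the series" means these compounds.

In a functional assay on the whole organism (strain Wistar) for inhibition, with Rattus norvegicus as the target, read by paw edema, with stated times of 1 h and 3 h, at a dose of 200 mg/kg by the oral route (a lower number here means less inhibition, a higher number more inhibition at the dose given (going by the name of the read-out)), compound 1 `CN(CC1CCC/C(=C\c2ccccc2)C1=O)c1ccccc1` gives 76.6%. Compound 2 `Cc1ccc(N(C)CC2CCC/C(=C\c3ccccc3)C2=O)cc1` differs from it only by methyl in place of hydrogen on an aromatic carbon, and in this assay compound 2 gives 25.5%, so that a number 51.1 percentage points lower from compound 1 to compound 2 (beyond the scatter). Compound 3 `COc1ccc(C2(O)/C(=C/c3ccccc3)CCCC2CN(C)c2ccccc2)cc1` has a different core; the difference between the core of compound 3 and the core of compound 1 is not broken down here. In this assay compound 3 gives 38.3%. For the measured compounds named here, compound 4 `COc1ccc(C2(O)/C(=C/c3ccc(C)cc3)CCCC2CN(C)c2ccccc2)cc1` is not yet measured and differs from compound 3 by methyl in place of hydrogen on an aromatic carbon, at the same place, so this is the same change as the one from compound 1 to compound 2. Since that earlier change brought a number 51.1 percentage points lower from compound 1 to compound 2 (beyond the scatter), and compound 3 starts at 38.3%, the account expects a downward step of smaller size, a number 23.3 percentage points lower from compound 3 to compound 4 (beyond the scatter), resting on a single prior pair only. Compound 4 is therefore estimated at 15%, with a range from 2% to 38%, in this assay.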

Compound 4, a percentage reported as inhibition, in the whole organism at one dose (the size of the read-out at that dose, not a potency): 17%
For compound 4 the middle estimate is 2 percentage points below the measured one, within the range that was stated.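

In this assay, methyl in place of hydrogen on an aromatic carbon again comes with a drop on a second core, a number 21.3 percentage points lower from compound 3 to compound 4 (beyond the scatter). The direction of the change therefore carries over between these two cores, but its size does not, and the two steps cannot be treated as one fixed increment: the same change on two cores in this assay, a number 51.1 percentage points lower (beyond the scatter) from compound 1 to compound 2 and a number 21.3 percentage points lower (beyond the scatter) from compound 3 to compound 4, 29.8 percentage points apart, beyond the scatter of two such steps. For the compounds shown here, with only two pairs, this does not show that the downward direction would hold on any further core, and the numbers alone do not say what sets the size of the step on each core.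

The compounds shown leave open whether another group in the same place, such as ethyl, a chlorine atom or a carboxylic acid, would follow the methyl or behave differently. They also leave open whether the gap between the two steps would persist at other doses, since each value is a single read-out at one dose and not a potency.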